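Methyl Replaced by Nitro on the Ester Phenyl Ring

A few compounds are considered here, and "the series" means these few. Any claim that something is new, unique, unknown or untested is made for them only; others in the source may bear on it.

Two esters of the shared core have been measured so far. Compound 1 `CC1=CC[C@H](C(C)C)c2cc(C)c(OC(=O)c3ccccc3)cc21` gives 49.5% in a functional assay on HCT-15 cells (Homo sapiens) for antiproliferative activity, read by sulforhodamine B assay, with a stated time of 48 h, tested at 50 uM; a higher number here means more inhibition at the concentration tested (going by the name of the read-out), a lower number less inhibition. Among the compounds with values here, compound 2 `CC1=CC[C@H](C(C)C)c2cc(C)c(OC(=O)c3cccc(C)c3)cc21` gives 5.3% in this assay and so stands lowest of the two numbers recorded; the single step connecting the pair, a number 44.2 percentage points lower from compound 1 to compound 2 (beyond the scatter), came from methyl in place of hydrogen on an aromatic carbon.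

Compound 3 `CC1=CC[C@H](C(C)C)c2cc(C)c(OC(=O)c3cccc([N+](=O)[O-])c3)cc21` has not yet been measured. It differs from compound 2 by nitro in place of methyl on an aromatic carbon: 3-methylphenyl becomes 3-nitrophenyl, the group sitting on an aromatic carbon of a six-membered aromatic ring of carbon only, meta to a large group.

Within the data shown here, only one measured step bears on this change, and only loosely: the step from compound 1 to compound 2 shows that a methyl at this place lowered the read-out sharply. Nothing measured tells how a nitro group at the same place behaves, so the uncertainty is wide. Compound 3 is expected to lie near 20%, within a range from 0% to 55%, and the estimated step of a number 14.7 percentage points higher from compound 2 to compound 3 (beyond the scatter) is an upward one that may or may not clear the scatter.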

Compound 3, a percentage reported as inhibition, at one concentration (the size of the read-out at that concentration, not a potency): 45.9%
Compound 3: middle estimate off by 25.9 percentage points, on the low side; the range from low to high includes it.
By their numbers in this assay, from the lowest: compound 2; then compounds 3 and 1 (each within the scatter of the next).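

In this assay, the low number of compound 2 turns out not to be a general result of putting a group at this place: nitro in place of methyl on the same aromatic carbon gives a number 40.6 percentage points higher from compound 2 to compound 3 (beyond the scatter) and so recovers nearly all that methyl had cost. The comparison with the ester of compound 1, which carries hydrogen at this place, gives a number 3.6 percentage points lower from compound 1 to compound 3 (within the scatter) and so shows that a group meta to a large group can be carried without a measurable change in the read-out; among these three compounds, only compound 2, with its 3-methylphenyl, stands apart. No measurement available here accounts for the wide gap between methyl and nitro on this carbon.

The three compounds leave open where other groups would fall at this place, for instance an amine, a carboxylic acid or a longer chain such as ethyl, and so whether compound 2 is an isolated case or part of a wider trend. From the compounds shown here alone, since each number is the size of the read-out at one concentration, how compound 1 and compound 3 compare in potency also remains open.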